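The compounds below may be only part of what the source reports. "The series", "measured", "known", "first", "only" and "open" are said of these compounds alone.

In a functional assay on HL-60 cells (Homo sapiens) for antiproliferative activity, read by sulforhodamine B assay, with a stated time of 72 h (on this read-out higher numbers stand for weaker inhibition and lower numbers for stronger inhibition), compound 1 `CN(C)C(=S)N/N=C/c1ccc2ccccc2n1` gives 50 nM. Compound 3 `NC(=S)N/N=C/c1ccc2ccccc2n1` gives > 100000 nM, which is a limit of the assay and not a number. Compound 4 `S=C(N/N=C/c1ccc2ccccc2n1)Nc1cccc(Cl)c1` has 3-chlorophenyl in place of hydrogen on an amide-type nitrogen. Among the measured compounds shown here, the one measured step that bears on this is an at least 2000-fold higher number from compound 1 to compound 3 (3.30 log units; beyond the scatter), a large change beyond the scatter on going from dimethylamino to amino. Compound 2 `FC(F)(F)c1ccccc1NC(=S)N/N=C/c1ccc2ccccc2n1`, with a trifluoromethyl-bearing phenyl group on the same kind of nitrogen, gives 13200 nM and is the nearest guide. A large move towards a lower number is therefore expected in this assay, although the starting point is only a limit. The estimated step is an at least 16-fold lower number from compound 3 to compound 4 (1.22 log units; beyond the scatter). For compound 4 the expected value is 6000 nM, with an estimated range of 800 nM to 40000 nM.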

Compound 4, half-maximal inhibitory concentration: 28800 nM
For compound 4 the middle estimate is 4.8-fold (0.68 log units) below the measured one; the range from low to high includes it.
By their numbers in this assay, from the lowest: compound 1; then compound 2; then compound 4. At a limit, above all of these: compound 3.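

In this assay, 3-chlorophenyl in place of hydrogen on an amide-type nitrogen gives an at least 3.4-fold lower number from compound 3 to compound 4 (0.54 log units; beyond the scatter), so this nitrogen can carry an aromatic ring and still return a readable number. Compound 3 stands at a limit of the assay and not at a number: the limit of > 100000 nM in this assay, at which 1 of the 4 values shown sits.
The true size of the step therefore cannot be read, only its lower bound.

Whether the ring or its chlorine accounts for the change stays open. Also open, as far as these compounds go, is how plain phenyl, or a methyl or cyclohexyl, would read on this nitrogen.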